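The source may report more compounds than this note shows. Statements on the series, on what has been measured and on what is new or still open speak of the compounds shown alone.

Compound 1, `CCOC(=O)c1ccc(/N=N/N(C)CC(C)C)cc1`, gives 2.8.
Compound 2, `CN(CCO)/N=N/c1ccccc1C(N)=O`, gives 3.07.
Compound 3, `CCCCN(C)/N=N/c1ccc([N+](=O)[O-])cc1C(N)=O`, gives 3.08.

These three numbers come from a functional assay on L1210 cells (Mus musculus) for antiproliferative activity; on this read-out higher numbers stand for higher potency (the scale is a negative logarithm) and lower numbers for lower potency. Compound 1 sits within the usual scatter of both compound 2 and compound 3, so the three measured compounds cannot be told apart on this assay; none can be called more or less potent than another.

Compound 4, `CCOC(=O)c1ccc(/N=N/N(C)CC)cc1`, has not been measured. It differs from compound 1 in one place: methyl in place of isopropyl on a saturated chain carbon bound to an amine nitrogen. The rest of the structure, the shared core with its ethyl ester, stays the same. The saturated chain on the amine nitrogen is shortened from isobutyl to ethyl, and the amine becomes ethyl(methyl)amino instead of isobutyl(methyl)amino.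

Going by the values given here, no measured pair shows what such a change does here. With nothing else to go on, the expected step from compound 1 to compound 4 is small, a number 0.10 log units higher from compound 1 to compound 4 (within the scatter), and likely within the scatter in either direction. Compound 4 is therefore estimated at 2.9, with a range from 2.4 to 3.4.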

Compound 4, logarithm of the reciprocal of the active concentration, log(1/C): 3.01
Estimate against measurement, compound 4: 0.11 log units below, within the range that was stated.
By their numbers in this assay, from the lowest: compounds 1, 4, 2 and 3 (each within the scatter of the next).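

Going by these compounds alone, compound 1 and compound 4 form the first pair here that differs in one place, so this change on a saturated chain carbon bound to an amine nitrogen can be read on its own. In this assay, putting methyl in place of isopropyl, which turns isobutyl into ethyl, gives a step of a number 0.21 log units higher from compound 1 to compound 4 (within the scatter), so the two chains cannot be told apart on this read-out. No other measurement here bears on why the step has this size.

Still open, from the compounds shown here alone, is whether a longer chain, such as octyl, or a chain ending in a carboxylic acid at this amine nitrogen would stand apart from these two. Also open, going by these compounds, is whether the same shortening would read alike on the core of compound 3, which carries a nitro group and an amide instead of the ethyl ester.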